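Cytotoxicity notes: anilide change from compound 3 to compound 4

The source may report more compounds than this note shows. Statements on the series, on what has been measured and on what is new or still open speak of the compounds shown alone.

Compound 3 `Cc1cc(C)cc(S(=O)(=O)n2c(SCC(=O)Nc3ccccc3Br)nc3ccc(Cl)cc32)c1` stands lowest of the two numbers in an ADME assay on MT4 cells (Homo sapiens) for cytotoxicity (on this read-out lower numbers stand for higher toxicity in this test and higher numbers for lower toxicity in this test), giving 145000 nM; its nearest neighbour is compound 1 `Cc1cc(C)cc(Cn2c(SCC(=O)Nc3ccccc3Br)nc3ccc(Cl)cc32)c1`, which gives 174000 nM, a gap within the scatter. Compound 2 `Cc1cc(C)cc(S(=O)(=O)n2c(SCC(=O)Nc3ccccc3Br)nc3ccccc32)c1` reports only a limit in this assay, >= 235000 nM. That single value sits at the limit of >= 235000 nM in this assay, at which 1 of the 3 values shown sits. Two steps have been measured, a 1.2-fold lower number from compound 1 to compound 3 (0.08 log units; within the scatter) and an at least 1.6-fold lower number from compound 2 to compound 3 (0.20 log units; that floor lies within the scatter); neither touches the amide end of the molecule, and both lie within the scatter.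

Compound 4 `Cc1cc(C)cc(S(=O)(=O)n2c(SCC(=O)Nc3ccc(C)cc3Cl)nc3ccc(Cl)cc32)c1` differs from compound 3 by 2-chloro-4-methylphenyl in place of 2-bromophenyl on an amide-type nitrogen. Going by the values given here, no measured step bears on this part of the structure, so the expectation rests on compound 3 alone: the step is expected to be a 1.0-fold higher number from compound 3 to compound 4 (0.01 log units; within the scatter), nothing beyond the scatter. Compound 4 is therefore estimated at 150000 nM, within 70000 nM to 300000 nM.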

Compound 4, half-maximal cytotoxic concentration: > 234000 nM
Compound 4 was reported as a limit; the forecaster's own chance of this, stated with the estimate: 25%; at least 1.5-fold (0.19 log units) between middle value and limit.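

Going by these compounds alone, this is the first measured change at the amide end of the series: 2-chloro-4-methylphenyl in place of 2-bromophenyl on the amide-type nitrogen gives, in this assay, an at least 1.6-fold higher number from compound 3 to compound 4 (0.20 log units; that floor lies within the scatter). The floor of that step lies within the scatter, and the change shows no higher toxicity in this test. Compound 4 has only a limit here, not a number: the limit of > 234000 nM in this assay, at which 1 of the 4 values shown sits.

Open, going by these compounds, is how the swap of bromo for chloro and the added methyl each count on their own. Also open, on these data alone, is how an amine or a carboxylic acid on this phenyl ring would read in this assay.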